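Methyl on the sulfonamide nitrogen of compound 2

A few compounds are considered here, and "the series" means these few. Any claim that something is new, unique, unknown or untested is made for them only; others in the source may bear on it.

Compound 2 `CCCS(=O)(=O)Nc1ccc(F)c(C(=O)c2n[nH]c3ncc(-c4ccc(S(N)(=O)=O)cc4)cc23)c1F` gives 0.25% in an assay for binding affinity to dual specificity mitogen-activated protein kinase kinase 4 (Homo sapiens), read by KINOMEscan, tested at 100 nM (on this read-out higher numbers stand for a weaker effect at the one concentration tested and lower numbers for a stronger effect), the lower of the two numbers recorded: compound 1 `CCCS(=O)(=O)Nc1ccc(F)c(C(=O)c2n[nH]c3ncc(-c4cccc(Cl)c4)cc23)c1F` gives 40%, and the step of a number 39.8 percentage points lower from compound 1 to compound 2 (beyond the scatter) came from exchanging the whole aryl group. Compound 3 `CCCS(=O)(=O)Nc1ccc(F)c(C(=O)c2n[nH]c3ncc(-c4ccc(S(=O)(=O)NC)cc4)cc23)c1F` differs from compound 2 by methyl in place of hydrogen on a sulfonamide nitrogen. Within the data shown here, no measured step touches the sulfonamide alone, so the one step to hand bears only loosely; the change is small and compound 2 already sits near the floor of the read-out. Compound 3 is therefore expected to stay close, with a number 0.8 percentage points higher from compound 2 to compound 3 (within the scatter) within the scatter, estimated at 1% (0.1% to 10%).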

Compound 3, a percentage reported as activity, at one concentration (the size of the read-out at that concentration, not a potency): 1.2%
For compound 3 the middle estimate is 0.2 percentage points below the measured one, and the stated range covers the measured number.
By their numbers in this assay, from the lowest: compounds 2 and 3 (each within the scatter of the next); then compound 1.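

In this assay, methyl on the sulfonamide nitrogen brings no readable change, with a number 1 percentage points higher from compound 2 to compound 3 (within the scatter), so the unsubstituted sulfamoyl group is not required for a low number at this one concentration. The large difference from the 3-chlorophenyl compound also holds for 4-(methylsulfamoyl)phenyl, with a number 38.8 percentage points lower from compound 1 to compound 3 (beyond the scatter). Nothing available explains either step.

Any difference in the strength of effect between compound 2 and compound 3 stays hidden at this single concentration. Open too, on these data alone, is how this nitrogen responds to an ethyl or a longer chain, and whether a carboxylic acid can replace the sulfamoyl group.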